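Methoxy for Trifluoromethyl on a Shared Urea Core

This account rests on a few compounds, and the source may have more. Where it says the series, first, only, none or still open, it means among the compounds named here.

Compound 1 `COc1ccc(F)cc1Nc1cc(NC(=O)Nc2c(Cl)cccc2Cl)ncn1`: 73.1%
Compound 2 `COc1ccc(C(F)(F)F)cc1Nc1cc(NC(=O)Nc2c(Cl)cccc2Cl)ncn1`: 69.1%

Both compounds were tested in a functional assay on NCI-H1581 cells (Homo sapiens) for inhibition, read by MTT assay, with a stated time of 48 h, tested at 10 uM; on this read-out lower numbers stand for less inhibition and higher numbers for more inhibition at the one concentration tested (going by the name of the read-out). Compound 2 stands at the lower of the two numbers shown, yet the step of a number 4 percentage points lower from compound 1 to compound 2 (within the scatter) is within the scatter, so the two compounds cannot be told apart on this read-out. Compound 3 `COc1ccc(OC)c(Nc2cc(NC(=O)Nc3c(Cl)cccc3Cl)ncn2)c1` is not yet measured. It differs from compound 2 by methoxy in place of trifluoromethyl on an aromatic carbon; the rest of the shared core is unchanged.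

Among the compounds with values here, only one measured step exists, and it does not cover this exchange: a number 4 percentage points lower from compound 1 to compound 2 (within the scatter) swaps a fluoro for a trifluoromethyl at the same place and stays within the scatter. Within the data shown here, there is thus no measured step that shows what happens when a methoxy enters at this position, and nothing in the data points to a movement beyond the scatter in either direction. The step of a number 0.9 percentage points higher from compound 2 to compound 3 (within the scatter) is therefore expected to be small. Compound 3 is estimated at 70%, with a range from 55% to 82%.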

Compound 3, a percentage reported as inhibition, at one concentration (the size of the read-out at that concentration, not a potency): 93.1%
The estimate for compound 3 lay 23.1 percentage points below the measured number; the measured number lies above the stated range.
By their numbers in this assay, from the lowest: compounds 2 and 1 (each within the scatter of the next); then compound 3.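

Within the data shown here, until this result, the number seemed to stay level when the group at this position changed, since fluoro and trifluoromethyl could not be told apart. In this assay the exchange of trifluoromethyl for methoxy gives a number 24 percentage points higher from compound 2 to compound 3 (beyond the scatter) and the exchange of fluoro for methoxy gives a number 20 percentage points higher from compound 1 to compound 3 (beyond the scatter) so the group at this place can matter, and of the three groups shown, methoxy is the one that stands apart. Nothing available explains why this group gives the higher number.

With only fluoro, trifluoromethyl and methoxy shown at this place, it remains open whether the rise is particular to methoxy or would also appear with a longer chain on the oxygen, such as ethoxy, or with a hydroxyl group or an amine. A reading at a single concentration also leaves open how compound 3 would compare on a full potency measurement, and whether the same exchange would give a similar rise in other cell lines or on a different core.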